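From Propyl to Tert-Butyl on a Shared Core

The compounds below may be only part of what the source reports. "The series", "measured", "known", "first", "only" and "open" are said of these compounds alone.

In a functional assay on MCF7 cells (Homo sapiens) for antiproliferative activity, read by MTT assay, with a stated time of 72 h (on this read-out lower numbers stand for stronger inhibition and higher numbers for weaker inhibition), compound 1 `CC(=O)/C=C/c1cnc(C)c2c1COC(C)(C)O2` gives 6600 nM and compound 2 `CCCC1OCc2c(/C=C/C(C)=O)cnc(C)c2O1` gives 2200 nM as the lower of the two numbers, a gap beyond the scatter. Compound 3 `CC(=O)/C=C/c1cnc(C)c2c1COC(C(C)(C)C)O2` has tert-butyl in place of propyl on a saturated ring carbon of compound 2 (tert-butyl in place of propyl on a saturated ring carbon). Among the compounds with values here, no measured pair shows this exact change, so the forecast is loose. In this assay a slightly higher number is expected, with the estimated step (a 1.4-fold higher number from compound 2 to compound 3 (0.13 log units; within the scatter)) staying within the scatter. The estimate for compound 3 is 3000 nM (expected range 1100 nM to 8000 nM).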

Compound 3, half-maximal inhibitory concentration: 4100 nM
Estimate against measurement, compound 3: 1.4-fold (0.14 log units) below; the measured number falls inside the stated range.
By their numbers in this assay, from the lowest: compounds 2, 3 and 1 (each within the scatter of the next, the first and the last beyond it).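

In this assay, putting tert-butyl in place of propyl on the saturated ring carbon between two ring oxygen atoms gives a 1.9-fold higher number from compound 2 to compound 3 (0.27 log units; within the scatter). Compound 2 and compound 3 therefore cannot be told apart on this read-out, and this position accepts either group without a change beyond the usual scatter. No measurement shown offers an explanation for this result.

Going by these compounds, how this ring carbon would respond to a longer chain, such as octyl, or to an amine or a carboxylic acid remains open.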